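Swapping Bromo for Chloro on the Aniline Ring

A few compounds are considered here, and "the series" means these few. Any claim that something is new, unique, unknown or untested is made for them only; others in the source may bear on it.

The shared core appears in compound 1 `COC1=CC(=O)c2ncsc2C1=O`, for which a functional assay on HepG2 cells (Homo sapiens) for cytotoxicity, read by MTT assay (a higher number here means a weaker inhibitor, a lower number a stronger inhibitor), shows "not tested" (no result reported). Compound 2 `Cc1nc2c(s1)C(=O)C=C(Nc1ccc(C(F)(F)F)cc1)C2=O` carries a trifluoromethyl group on its outer ring. In this assay compound 2 reaches only a limit of the assay, > 100 ug/mL, with no number behind it. That is the limit of > 100 ug/mL in this assay, at which 1 of the 3 values shown sits. Among the measured compounds shown here, compound 3 `Cc1nc2c(s1)C(=O)C=C(Nc1cccc(Br)c1)C2=O` carries a bromo group instead, and in this assay compound 3 gives 15 ug/mL, the only actual number among the three entries. Compound 4 `Cc1nc2c(s1)C(=O)C=C(Nc1cccc(Cl)c1)C2=O` is the next step: chloro in place of bromo on an aromatic carbon, on an aromatic carbon of a six-membered aromatic ring of carbon only, meta to a large group. For the measured compounds named here, no step between measured compounds is available to size this change, and the swap is expected to move the value in this assay by no more than the usual scatter, in either direction. The estimate for compound 4 is therefore 20 ug/mL, spanning 7 ug/mL to 60 ug/mL. This means an expected step of a 1.3-fold higher number from compound 3 to compound 4 (0.12 log units; within the scatter), within that scatter.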

Compound 4, half-maximal inhibitory concentration: 5.7 ug/mL
Compound 4: middle estimate off by 3.5-fold (0.55 log units), on the high side; measured number below the stated range.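

In this assay, the exchange of chloro for bromo gives a 2.6-fold lower number from compound 3 to compound 4 (0.42 log units; beyond the scatter), so the chloro compound is the stronger inhibitor of the pair. Among the compounds shown here, this is the first measured step at this place on the ring, and it shows that the read-out responds to a swap between two halogens, even though neither group brings a ring, a charge, or any hydrogen-bond donors or acceptors. Nothing shown here explains why chloro and bromo differ in this way.

The compounds shown leave open what fluoro, a methoxy group or an amine would do at the same place. They also leave open whether the step would keep its size and direction if chloro and bromo were exchanged elsewhere on this ring.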